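Removing a Methyl Group: What Compound 4 Should Give

A few compounds are considered here, and "the series" means these few. Any claim that something is new, unique, unknown or untested is made for them only; others in the source may bear on it.

Measured so far:
- Compound 1, `O=C(/C=C/c1coc2cc(O)ccc2c1=O)NCc1ccccc1`: in a functional assay on HeLa cells (Homo sapiens) for inhibition, read by MTT assay, with a stated time of 48 h (on this read-out lower numbers stand for stronger inhibition and higher numbers for weaker inhibition), compound 1 gives > 100000 nM, which is a limit of the assay and not a number.
- Compound 2, `COc1ccc2c(=O)c(/C=C/C(=O)NCc3ccccc3)coc2c1`: in this assay compound 2 gives 33400 nM.
- Compound 3, `COc1ccc(NC(=O)/C=C/c2coc3cc(OC)ccc3c2=O)cc1`: in this assay compound 3 gives 13000 nM.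

Compound 3 has the lowest of the two numbers. The difference between the cores of compound 2 and compound 3 is 4-methoxyphenyl in place of benzyl on an amide-type nitrogen, and that change brought a 2.6-fold lower number from compound 2 to compound 3 (0.41 log units; beyond the scatter).

From compound 2 to compound 1 the change is hydrogen in place of methyl on an oxygen on an aromatic ring, and it brought an at least 2.9-fold higher number from compound 2 to compound 1 (0.47 log units; beyond the scatter). The size of that step is known only as a bound because of the limit of > 100000 nM in this assay, at which 1 of the 3 values shown sits.

Compound 4, `COc1ccc(NC(=O)/C=C/c2coc3cc(O)ccc3c2=O)cc1`, is not yet measured. It differs from compound 3 by hydrogen in place of methyl on an oxygen on an aromatic ring, the same change, at the same place, as from compound 2 to compound 1. Compound 4 is therefore expected to give a weaker result, an expected step of a 3.8-fold higher number from compound 3 to compound 4 (0.59 log units; beyond the scatter), resting on an at least 2.9-fold higher number from compound 2 to compound 1 (0.47 log units; beyond the scatter). For compound 4 the estimate is 50000 nM, expected between 20000 nM and 150000 nM, with a real chance that only a limit is reported.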

Compound 4, half-maximal inhibitory concentration: > 100000 nM
Compound 4 ended at the assay's limit; the forecaster's own chance of this, stated with the estimate: 30%; middle value at least 2.0-fold (0.30 log units) from the limit.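

In this assay compound 4 gives > 100000 nM, which is a limit of the assay and not a number. Replacing methoxy with hydroxy weakens the result on both cores, here with an at least 7.6-fold higher number from compound 3 to compound 4 (0.88 log units; beyond the scatter), so the direction of the change carries over from the core of compound 2 to the core of compound 3: the same change on two cores in this assay, an at least 2.9-fold higher number (0.47 log units; beyond the scatter) from compound 2 to compound 1 and an at least 7.6-fold higher number (0.88 log units; beyond the scatter) from compound 3 to compound 4; the limit leaves it open whether they differ What this does not show is whether the size of the step carries over too, and the step from compound 1 to compound 4 cannot be read, because both compounds sit at the same limit: the limit of > 100000 nM in this assay, at which 2 of the 4 values shown sit.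

The compounds shown leave open whether the weaker result depends on the hydroxy group itself, or whether a longer chain on that oxygen, such as ethoxy in place of methoxy, would behave differently. From the compounds shown here alone, only benzyl and 4-methoxyphenyl appear on the amide-type nitrogen, so it also remains open how the same change behaves with another group there, such as a plain phenyl or a chain ending in a carboxylic acid.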